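This account rests on a few compounds, and the source may have more. Where it says the series, first, only, none or still open, it means among the compounds named here.

Measured so far:
compound 1, `ClCc1ccccc1Cn1cnc2c(Cl)nc(Cl)nc21`, 490 nM
compound 2, `ClCc1ccccc1Cn1cnc2c(Cl)ncnc21`, 2340 nM
compound 3, `ClCc1cccc(Cn2cnc3c(Cl)ncnc32)c1`, 24000 nM

All three were tested in a functional assay on RXF 393 cells (Homo sapiens) for cytotoxicity, read by sulforhodamine B assay, with a stated time of 48 h; on this read-out lower numbers stand for stronger inhibition of growth and higher numbers for weaker inhibition of growth. Compound 1 and compound 2 share a core and differ in a single place: chloro in place of hydrogen on an aromatic carbon. That change produced a step of a 4.8-fold lower number from compound 2 to compound 1 (0.68 log units; beyond the scatter). Compound 3 is built from the same atoms as compound 2, joined differently; the difference between the two cores is not broken down here. In this assay compound 3 gives the highest number of the three. Compound 4, `ClCc1cccc(Cn2cnc3c(Cl)nc(Cl)nc32)c1`, has not been measured yet; it differs from compound 3 by chloro in place of hydrogen on an aromatic carbon, the same change as that seen between compound 2 and compound 1. Because the earlier step was a 4.8-fold lower number from compound 2 to compound 1 (0.68 log units; beyond the scatter), a step of similar size is expected from compound 3 to compound 4, namely a 4.4-fold lower number from compound 3 to compound 4 (0.64 log units; beyond the scatter), although a different core need not respond alike. Compound 4 is accordingly estimated at 5500 nM, between 2000 nM and 15000 nM.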

Compound 4, concentration for total growth inhibition: 2090 nM
Compound 4: the middle estimate sits 2.6-fold (0.42 log units) above what was measured; the range from low to high includes it.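

In this assay, chloro in place of hydrogen on an aromatic carbon, between two ring nitrogen atoms, gave an 11-fold lower number from compound 3 to compound 4 (1.06 log units; beyond the scatter). The change lowered the number on both cores, and the sizes of the two steps cannot be told apart: the same change on two cores in this assay, a 4.8-fold lower number (0.68 log units; beyond the scatter) from compound 2 to compound 1 and an 11-fold lower number (1.06 log units; beyond the scatter) from compound 3 to compound 4, 2.4-fold (0.38 log units) apart, within the scatter of two such steps. Two cores are a small sample, however, so this does not show that the step would hold on a third core, and it does not explain why the number falls.

The compounds shown carry only hydrogen or chloro at this place. On these data alone, whether an amine, a methoxy group or a longer chain there would also lower the number remains open.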